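This account rests on a few compounds, and the source may have more. Where it says the series, first, only, none or still open, it means among the compounds named here.

In a functional assay on the whole organism with Mus musculus as the target (on this read-out higher numbers stand for an effect only at larger amounts of compound and lower numbers for an effect already at smaller amounts), compound 1 (`O=C(/C=C1\CCc2ccccc21)NC1CC1`) gives 150 mg/kg. Within the data shown here, this puts it at the upper end of the numbers so far, within the scatter of compound 2 (`O=C(/C=C1\CCc2c(F)cccc21)NC1CC1`) at 126 mg/kg. Among the measured compounds shown here, compound 3 (`O=C(/C=C1\CCc2c1ccc(F)c2F)NC1CC1`) gives 62 mg/kg, the lowest number so far.

The change now in view leads to compound 4 (`NC(=O)/C=C1\CCc2ccccc21`): hydrogen in place of cyclopropyl on an amide-type nitrogen. Neither measured step touches this nitrogen. Both are fluoro in place of hydrogen on an aromatic carbon: a 1.2-fold lower number from compound 1 to compound 2 (0.08 log units; within the scatter) and a 2.0-fold lower number from compound 2 to compound 3 (0.31 log units; beyond the scatter). They therefore say nothing direct about the effect of removing the cyclopropyl, and they give no direction for it. They show only the sizes met so far on the shared core, one within the scatter and one modest.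

With no measured change at the amide nitrogen, a step beyond the scatter is not expected in this assay, though one cannot be excluded. The expected step is a 1.3-fold lower number from compound 1 to compound 4 (0.10 log units; within the scatter), and this small lean carries little weight. For compound 4 the estimate is 120 mg/kg, with an expected range from 45 mg/kg to 300 mg/kg.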

Compound 4, dose for half-maximal effect: 108 mg/kg
Estimate against measurement, compound 4: 1.1-fold (0.05 log units) above; measured number inside the range.
By their numbers in this assay, from the lowest: compounds 3, 4, 2 and 1 (each within the scatter of the next, the first and the last beyond it).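

Notes on the amide-type nitrogen: in this assay, hydrogen in place of cyclopropyl gives a 1.4-fold lower number from compound 1 to compound 4 (0.14 log units; within the scatter), which is the first reading at this position and the first change in the series away from the aromatic carbons. On the unfluorinated core, the cyclopropyl with its three-membered ring is therefore not needed to keep the number within the scatter of compound 1, and the plain amide with its hydrogen on nitrogen serves as a working reference for this position. No supporting data bear on this result, so it stands as a bare observation of size at one position on one core.

The compounds shown do not tell whether a methyl, a longer chain such as n-butyl, or a larger ring such as cyclohexyl on this nitrogen would also stay within the scatter of compound 1, or whether a hydroxyl or an amine carried on such a chain would move the number beyond it. They also leave open whether the step from cyclopropyl to hydrogen keeps its size on the difluoro core of compound 3, where the fluoro groups are present.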